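Capping a hydroxy group on a weakly active core

The source may hold more compounds than are shown below. What is called first, only, known or untested is meant among the compounds shown, and "the series" means these compounds.

Among the measured compounds shown here, only two values are known for this small series. In a functional assay on HL-60 cells (Homo sapiens) for antiproliferative activity (on this read-out higher numbers stand for weaker inhibition and lower numbers for stronger inhibition), compound 1 `Oc1cccc2nccc(O)c12` gives > 30000 nM, which is a limit of the assay and not a number. For the measured compounds named here, compound 2 `COc1ccc(O)c2c(O)ccnc12` gives 17700 nM, the only true number so far. Compound 3 `COc1ccc(OC)c2c(O)ccnc12` differs from compound 2 by methyl in place of hydrogen on an oxygen on an aromatic ring, so hydroxy becomes methoxy. Going by the values given here, the one measured step that bears on this is an at least 1.6-fold lower number from compound 1 to compound 2 (0.22 log units; that floor lies within the scatter). It places methoxy on an aromatic carbon instead, stays within the scatter and rests on a limit, so it sets no firm size for the new change. In this assay no shift beyond the scatter is expected, and the estimated change is a 1.2-fold higher number from compound 2 to compound 3 (0.09 log units; within the scatter). For compound 3 the expected value is 22000 nM, with an estimated range from 8000 nM to 50000 nM.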

Compound 3, half-maximal inhibitory concentration: > 30000 nM
Compound 3: no number, only a limit (the forecaster's own chance of this, stated with the estimate: 40%); at least 1.3-fold (0.13 log units) between middle value and limit.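

Capping the hydroxy group as methoxy brought no improvement in this assay, and the change reads as an at least 1.6-fold higher number from compound 2 to compound 3 (0.22 log units; that floor lies within the scatter). For compound 3 the reading is a limit and not a number, so this step gives only a floor, and that floor does not establish a real loss. Compared with the earlier step, which placed methoxy on an aromatic carbon, this one shows that methyl on the oxygen leaves the series with a single true number, and the comparison is constrained by the assay's ceiling: the limit of > 30000 nM in this assay, at which 2 of the 3 values shown sit.

Going by these compounds, the true size of this step remains open, as does whether the free hydroxy itself is needed. Also open, on these data alone, is how a longer chain such as ethyl on this oxygen, or an amine in place of the hydroxy, would read.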